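The source may hold more compounds than are shown below. What is called first, only, known or untested is meant among the compounds shown, and "the series" means these compounds.

For the measured compounds named here, compound 1 `Clc1cccc(-n2cc(CSc3nc4ccccc4s3)nn2)c1` sits lowest of the two numbers so far: in a functional assay on the whole organism (strain Albino Wistar) for inhibition, with Rattus norvegicus as the target, read by paw edema, with stated times of 1 h and 5 h, at a dose of 10 mg/kg by the oral route (on this read-out higher numbers stand for more inhibition at the one dose given (going by the name of the read-out) and lower numbers for less inhibition), compound 1 gives 39.6%, while compound 2 `c1cncc(-n2cc(CSc3nc4ccccc4s3)nn2)c1` gives 56% in this assay, a rise of a number 16.4 percentage points higher from compound 1 to compound 2 (beyond the scatter). Compound 3 `OCC(O)Cn1cc(CSc2nc3ccccc3s2)nn1` differs from compound 1 by 2,3-dihydroxypropyl in place of 3-chlorophenyl on an aromatic nitrogen. Going by the values given here, the one measured step bears on the same position but swaps in a ring, not a chain, so it guides direction only loosely. A small upward step is expected, a number 4.4 percentage points higher from compound 1 to compound 3 (within the scatter), likely within the scatter. Compound 3 is therefore estimated at 44% in this assay, between 26% and 62%.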

Compound 3, a percentage reported as inhibition, in the whole organism at one dose (the size of the read-out at that dose, not a potency): 52.8%
For compound 3 the middle estimate is 8.8 percentage points below the measured one; measured number inside the range.
By their numbers in this assay, from the lowest: compound 1; then compounds 3 and 2 (each within the scatter of the next).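

A ring is not needed on this aromatic nitrogen: 2,3-dihydroxypropyl in place of 3-chlorophenyl gives a number 13.2 percentage points higher from compound 1 to compound 3 (beyond the scatter) in this assay, a rise of the same modest kind as the one seen with pyridin-3-yl. Set against pyridin-3-yl, the open chain gives a number 3.2 percentage points lower from compound 2 to compound 3 (within the scatter) and so cannot be ordered against that ring on these numbers. Nothing at hand accounts for either step. Still open, on these data alone, is how an amine, a carboxylic acid or a longer chain on this nitrogen would read in this assay, and whether the two hydroxyl groups of the chain both matter.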